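A few compounds are considered here, and "the series" means these few. Any claim that something is new, unique, unknown or untested is made for them only; others in the source may bear on it.

For the measured compounds named here, compound 2 `CCCC(CCC)Nc1cc(C)nc2c(-c3cnc(N(C)C)cc3C)c(C)nn12` gives 4.8 nM in an assay on CHO cells for binding affinity to corticotropin-releasing factor receptor 1 (Homo sapiens) (a lower number here means a stronger inhibitor, a higher number a weaker inhibitor), the lower of the two numbers measured so far, although the step of a 2.0-fold lower number from compound 1 to compound 2 (0.29 log units; within the scatter) lies within the scatter; compound 1 `CCC(CC)Nc1cc(C)nc2c(-c3cnc(N(C)C)cc3C)c(C)nn12` gives 9.4 nM. Compound 3 `CCC(COC)Nc1cc(C)nc2c(-c3cnc(N(C)C)cc3C)c(C)nn12` differs from compound 2 by 1-(methoxymethyl)propyl in place of 1-propylbutyl on a nitrogen on an aromatic ring. Going by the values given here, the only measured step is that from compound 1 to compound 2, and it was small; no measured pair touches the oxygen that enters. Compound 3 is therefore expected to give about 9 nM in this assay, within 3 nM to 30 nM, which would be a step of a 1.9-fold higher number from compound 2 to compound 3 (0.27 log units; within the scatter).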

Compound 3, inhibition constant: 260 nM
Compound 3: middle estimate off by 29-fold (1.46 log units), on the low side; measured number above the stated range.
By their numbers in this assay, from the lowest: compounds 2 and 1 (each within the scatter of the next); then compound 3.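

In this assay, this place on the nitrogen on an aromatic ring proves sensitive to the make-up of the chain, which the earlier small step did not reveal: 1-(methoxymethyl)propyl in place of 1-propylbutyl gives a 54-fold higher number from compound 2 to compound 3 (1.73 log units; beyond the scatter). Methoxy in place of methyl on the saturated chain gives a 28-fold higher number from compound 1 to compound 3 (1.44 log units; beyond the scatter), so the loss is large against both earlier compounds.

From the compounds shown here alone, whether a hydroxymethyl group, an amine or a longer ether chain at this place would fare the same remains open. The compounds shown offer no evidence for the reason behind this loss.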